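Cytotoxicity of a shared core across amide substituents

The source may report more compounds than this note shows. Statements on the series, on what has been measured and on what is new or still open speak of the compounds shown alone.

Measured compounds:
Compound 1 `Cc1cc(C)cc(S(=O)(=O)c2c(C(=O)NCC(=O)NCc3ccco3)[nH]c3ccc(Cl)cc23)c1`: in an ADME assay on MT4 cells (Homo sapiens) for cytotoxicity, read by MTT assay (on this read-out higher numbers stand for lower toxicity in this test and lower numbers for higher toxicity in this test), compound 1 gives > 50000 nM, which is a limit of the assay.
Compound 2 `Cc1cc(C)cc(S(=O)(=O)c2c(C(=O)NC(c3ccc(Cl)cc3)C3CC3)[nH]c3ccc(Cl)cc23)c1`: in this assay compound 2 gives > 47300 nM, again a limit of the assay.
Compound 3 `Cc1cc(C)cc(S(=O)(=O)c2c(C(=O)NC(C)c3ccccc3F)[nH]c3ccc(Cl)cc23)c1`: in this assay compound 3 gives > 51500 nM, also a limit of the assay.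

Compound 1 stands only at a limit in this assay, and the other two values shown are limits as well, as the limit of > 50000 nM in this assay, at which 1 of the 3 values shown sits, the limit of > 47300 nM in this assay, at which 1 of the 3 values shown sits, and the limit of > 51500 nM in this assay, at which 1 of the 3 values shown sits, record. The step that the two limits leave unreadable from compound 1 to compound 2 and the step that the two limits leave unreadable from compound 1 to compound 3, like the step that the two limits leave unreadable from compound 2 to compound 3, therefore cannot be sized.

Compound 4 `Cc1cc(C)cc(S(=O)(=O)c2c(C(=O)NCc3ccc4nc(N)[nH]c4c3)[nH]c3ccc(Cl)cc23)c1` carries the change (2-amino-1H-benzimidazol-6-yl in place of ((furan-2-yl)methyl)carbamoyl on a saturated chain carbon bound to an amide-type nitrogen). The measured steps that bear on it are the three steps from compound 1 and between compounds 2 and 3, all of which exchange the group on the amide-type nitrogen, and none of them gave a readable size. No step beyond the scatter can therefore be predicted in this assay, in either direction.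

For compound 4 the account expects a value of 60000 nM, with a range from 20000 nM to 200000 nM, most likely reported again as a limit. This estimated step that the limit leaves unreadable from compound 1 to compound 4 is expected to stay unreadable, as the measured steps were.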

Compound 4, half-maximal cytotoxic concentration: 5890 nM
The estimate for compound 4 lay 10-fold (1.01 log units) above the measured number; measured number below the stated range.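

In this assay, within the data shown here, putting 2-amino-1H-benzimidazol-6-yl in place of ((furan-2-yl)methyl)carbamoyl on a saturated chain carbon bound to an amide-type nitrogen produces an at least 8.4-fold lower number from compound 1 to compound 4 (0.92 log units; beyond the scatter), which shows that a change at this position can move the read-out towards higher toxicity in this test, something no earlier step could show. The picture is the same against the two other amide substituents, with an at least 8.7-fold lower number from compound 3 to compound 4 (0.94 log units; beyond the scatter) and an at least 8.0-fold lower number from compound 2 to compound 4 (0.90 log units; beyond the scatter), so the lower number does not depend on which earlier compound serves as the reference. Each of these sizes is only a minimum, because the starting values are limits of the assay, as for compound 1: the limit of > 50000 nM in this assay, at which 1 of the 4 values shown sits.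

The compounds shown leave open whether the lower number belongs to the amine on the 2-amino-1H-benzimidazol-6-yl group or to the two rings themselves, a question that the same rings without the amine, or with a carboxylic acid in its place, would address. On these data alone, whether a longer chain carrying the same group would keep this step also stays open.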